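This account rests on a few compounds, and the source may have more. Where it says the series, first, only, none or still open, it means among the compounds named here.

In a functional assay on A549 cells (Homo sapiens) for antiproliferative activity, read by MTT assay, with a stated time of 48 h (a higher number here means a weaker inhibitor, a lower number a stronger inhibitor), the two measured compounds stand as follows.
Compound 1, `CCOC(=O)CNc1nc(Nc2ccccc2)ncc1[N+](=O)[O-]`: > 100000 nM, a limit of the assay rather than a number.
Compound 2, `CCOC(=O)CN(Cc1ccccc1)c1nc(Nc2ccccc2)ncc1[N+](=O)[O-]`: > 100000 nM, likewise a limit of the assay.

Compound 2 therefore has no number of its own in this assay, only a limit. Among the measured compounds shown here, the single measured step, a step that the two limits leave unreadable from compound 1 to compound 2, cannot be sized because of the limit of > 100000 nM in this assay, at which 2 of the 2 values shown sit. For the measured compounds named here, compound 3, `CCOC(=O)CN(Cc1ccccc1)c1nc(Nc2cccc(OC)c2)ncc1[N+](=O)[O-]`, differs from compound 2 by methoxy in place of hydrogen on an aromatic carbon, and no measured step touches that ring. With both known values at a limit, no direction can be read, so compound 3 is expected to sit near the same limit, with an expected step that the limit leaves unreadable from compound 2 to compound 3. The estimate for compound 3 in this assay is 120000 nM, between 20000 nM and 800000 nM.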

Compound 3, half-maximal inhibitory concentration: > 100000 nM
Compound 3 ended at the assay's limit; the forecaster's own chance of this, stated with the estimate: 75%; the middle value lies beyond the limit too.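

No size can be read for the step from compound 2 to compound 3, because both compounds sit at a limit rather than at a number: the limit of > 100000 nM in this assay, at which 3 of the 3 values shown sit.
From the compounds shown here alone, whether methoxy or benzyl changes the activity of this series at all stays open.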